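This account rests on a few compounds, and the source may have more. Where it says the series, first, only, none or still open, it means among the compounds named here.

Compound 1 `C=CCNC(=O)n1c(-c2ccc(OC)cc2)cc(=O)c2c(OC)cc(OC)cc21` is the only one of the three measured compounds that yields a number in an ADME assay on BJ cells (Homo sapiens) for antiproliferative activity, with a stated time of 72 h; a lower number here means that less compound is needed, a higher number that more compound is needed for the effect; there compound 1 gives 74000 nM. Compound 2 `COC(=O)c1cc(=O)c2c(OC)cc(OC)cc2[nH]1` reaches only a limit of the assay, and in this assay compound 2 gives > 34400 nM. Compound 3 `COC(=O)c1cc(=O)c2c(OC)cc(OC)cc2n1C` likewise stops at a limit, and in this assay compound 3 gives > 37900 nM. Among the compounds with values here, the single measured step, a step that the two limits leave unreadable from compound 2 to compound 3, therefore cannot be read in size or direction. Compound 4 `COc1ccc(-c2cc(=O)c3c(OC)cc(OC)cc3n2S(=O)(=O)c2ccc(C#N)cc2)cc1` differs from compound 1 by (4-cyanophenyl)sulfonyl in place of allylcarbamoyl on an aromatic nitrogen. No readable measured step touches a substituent on this aromatic nitrogen, so nothing points up or down, and one expects a step that stays within the scatter, a 1.2-fold lower number from compound 1 to compound 4 (0.09 log units; within the scatter). Compound 4 is accordingly estimated at 60000 nM, within a range from 15000 nM to 200000 nM.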

Compound 4, half-maximal effective concentration: > 17200 nM
Compound 4 gave a limit, no number; the forecaster's own chance of this, stated with the estimate: 45%; the middle value does not contradict the limit.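

In this assay compound 4 gives > 17200 nM, which is a limit and not a number, so the step from compound 1 to compound 4 cannot be read. The compounds shown leave open how the substituent on this aromatic nitrogen affects the read-out.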